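Chloro on the N-Aryl Ring of Two Related Dihydropyridine Cores

The compounds below may be only part of what the source reports. "The series", "measured", "known", "first", "only" and "open" are said of these compounds alone.

Of the compounds shown here, three have so far been measured, and a fourth awaits measurement. Compound 1 `CCOC(=O)C1=C(C)N(c2ccccc2)C=CC1c1ccccc1` and compound 2 `CCOC(=O)C1=C(C)N(c2ccc(Cl)cc2)C=CC1c1ccccc1` share one core; compound 3 `COC(=O)C1=C(C)N(c2ccccc2)C=C(C)C1c1ccccc1` and the unmeasured compound 4 `COC(=O)C1=C(C)N(c2cccc(Cl)c2)C=C(C)C1c1ccccc1` share another, and the difference between the two cores is not broken down here. In a functional assay, tested at 100 ug/mL (on this read-out higher numbers stand for a weaker effect at the one concentration tested and lower numbers for a stronger effect), compound 1 gives -13.8%, compound 2 gives -20.8%, and compound 3 gives -14.1%. Compound 3 and compound 1 therefore show much the same read-out, and compound 2 lies only a little apart from either of them.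

Compound 2 differs from compound 1 by chloro in place of hydrogen on an aromatic carbon. This step gave a number 7 percentage points lower from compound 1 to compound 2 (within the scatter). Compound 4 differs from compound 3 by chloro in place of hydrogen on an aromatic carbon. Among the measured compounds shown here, this is the same kind of change as the one from compound 1 to compound 2, but not the same: in the first pair the chloro sits para to a large group, whereas in compound 4 it sits meta to a large group.

For the measured compounds named here, since the one measured instance of this change moved the read-out only within the scatter, a step of similar size is expected from compound 3 to compound 4 in this assay, namely a number 5.9 percentage points lower from compound 3 to compound 4 (within the scatter), resting on the single step from compound 1 to compound 2. Compound 4 is accordingly estimated to give -20% in this assay, with a range from -33% to -7%.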

Compound 4, a percentage reported as activity, at one concentration (the size of the read-out at that concentration, not a potency): -12%
Compound 4: middle estimate off by 8 percentage points, on the low side; low and high end bracket the measured number.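

In this assay, chloro in place of hydrogen on the aromatic ring gave a number 2.1 percentage points higher from compound 3 to compound 4 (within the scatter), and this step can now be set beside the earlier one: the same change on two cores in this assay, a number 7 percentage points lower (within the scatter) from compound 1 to compound 2 and a number 2.1 percentage points higher (within the scatter) from compound 3 to compound 4, 9.1 percentage points apart, within the scatter of two such steps Carried from the core of compound 1 to the core of compound 3, the change therefore stayed within the scatter on both cores, and the two steps cannot be told apart. Among the compounds shown here, this does not show that the effect of chloro transfers reliably between the cores, since neither step is large enough to stand out from the scatter, only two pairs are available, and the change is not identical in them: in compound 4 the chloro sits meta to a large group, whereas in compound 2 it sits elsewhere, so core and placement cannot be separated.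

The compounds shown leave open whether chloro at one and the same place would behave alike on both cores. They also leave open whether a different group on the N-aryl ring, such as an amine or a carboxylic acid, or a longer chain in place of the ester's alkyl group, would shift the read-out in this assay beyond the scatter.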